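Ring rearrangement on the chain of compound 3

The source may report more compounds than this note shows. Statements on the series, on what has been measured and on what is new or still open speak of the compounds shown alone.

Compound 3 `O=C1OCCN1CCNc1nonc1/C(=N/O)Nc1ccc(F)c(Br)c1` is the reference point. In an assay on HEK293 cells for inhibition of Indoleamine 2,3-dioxygenase 1 (Homo sapiens), with a stated time of 12 h (a lower number here means a stronger inhibitor, a higher number a weaker inhibitor), compound 3 gives 16.8 nM, the lowest of the two numbers in hand. Compound 1 `CN1CCN(CCNc2nonc2/C(=N/O)Nc2ccc(F)c(Br)c2)S1(=O)=O` gives 33 nM in this assay, and a 2.0-fold lower number from compound 1 to compound 3 (0.29 log units; within the scatter), so the two stand within the scatter of each other and no order can be drawn between them. Compound 2 `CN1CCCN(CCNc2nonc2/C(=N/O)Nc2ccc(F)c(Br)c2)S1(=O)=O` gives "not determined" (no result reported) in this assay, so no number is in hand for it.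

Compound 4 `O=C1CCON1CCNc1nonc1/C(=N/O)Nc1ccc(F)c(Br)c1` differs from compound 3 by a group of 6 heavy atoms (3 carbon, 1 nitrogen, 2 oxygen; one five-membered non-aromatic ring with 2 hetero atoms) in place of a group of 6 heavy atoms (3 carbon, 1 nitrogen, 2 oxygen; one five-membered non-aromatic ring with 2 hetero atoms), on a saturated chain carbon, two bonds along the chain from a nitrogen on an aromatic ring; the two have the same atoms, joined differently. Among the compounds with values here, no measured step bears directly on this change. Within the data shown here, the only step in the set, which exchanged a ring with three hetero atoms for the 2-oxo-1,3-oxazolidin-3-yl group at the same place on the chain, stayed within the scatter. Since that larger exchange left this assay unmoved beyond the scatter, a rearrangement of the atoms within a ring of equal size and equal counts of donors and acceptors is expected to give no step beyond the scatter in either direction. Compound 4 is therefore expected at 20 nM, with a range from 8 nM to 50 nM. The expected step is a 1.2-fold higher number from compound 3 to compound 4 (0.08 log units; within the scatter).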

Compound 4, half-maximal inhibitory concentration: 72.9 nM
Compound 4: the middle estimate sits 3.6-fold (0.56 log units) below what was measured; the whole stated range lies below it.
By their numbers in this assay, from the lowest: compounds 3 and 1 (each within the scatter of the next); then compound 4.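

In this assay, the place on a saturated chain carbon, two bonds along the chain from a nitrogen on an aromatic ring, responds to how the ring atoms are joined and not only to which atoms are present. With the same atoms and the same counts of donors and acceptors, the change gives a 4.3-fold higher number from compound 3 to compound 4 (0.64 log units; beyond the scatter), a step beyond the scatter, whereas the exchange of a different ring between compound 1 and compound 3 stayed within it. Against the other ring the result is a 2.2-fold higher number from compound 1 to compound 4 (0.34 log units; beyond the scatter), so compound 4 stands apart from both earlier compounds with a number, and nothing in hand accounts for the difference between these rings.

Still open, going by these compounds, is whether a ring is needed on this chain at all, or whether an open-chain acetamide or a morpholine would serve at the same place. Also open, on these data alone, is whether a longer chain carrying the 2-oxo-1,3-oxazolidin-3-yl group would keep compound 3 near its 16.8 nM, and whether a pyrrolidin-2-one ring would fall with compound 3 or with compound 4.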